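Amide variation on a shared core: anilide step

This account rests on a few compounds, and the source may have more. Where it says the series, first, only, none or still open, it means among the compounds named here.

Compound 3 `COc1ccc2c(=O)c(/C=C/C(=O)NCc3ccccc3)coc2c1` carries a benzyl group on the amide nitrogen. In a functional assay (QGY7701 cells, Homo sapiens) for inhibition, read by MTT assay, with a stated time of 48 h (a lower number here means a stronger inhibitor, a higher number a weaker inhibitor), compound 3 gives > 100000 nM, which is a limit of the assay and not a number. Compound 1 `COc1ccc2c(=O)c(/C=C/C(=O)Nc3cccc(C)c3)coc2c1` gives > 100000 nM in this assay, likewise a limit. Compound 2 `COc1ccc2c(=O)c(/C=C/C(=O)Nc3cccc(Cl)c3)coc2c1` gives > 100000 nM in this assay, again a limit. All three values stand at the limit of > 100000 nM in this assay, at which 3 of the 3 values shown sit, so compound 3 cannot be placed relative to the others. The steps a step that the two limits leave unreadable from compound 1 to compound 2, a step that the two limits leave unreadable from compound 1 to compound 3 and a step that the two limits leave unreadable from compound 2 to compound 3 are for that reason not readable in size.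

Compound 4 `COc1ccc2c(=O)c(/C=C/C(=O)Nc3ccccc3)coc2c1` differs from compound 3 by phenyl in place of benzyl on an amide-type nitrogen. Among the measured compounds shown here, no measured step bears on this change in a readable way; the two anilides, compound 1 and compound 2, and the benzylamide, compound 3, all sit at the same limit. The step of a number no higher from compound 3 to compound 4 (the limit leaves the size open) is therefore expected to be none beyond the scatter, with the value most likely again a limit. Compound 4 is estimated at 100000 nM, within a range from 30000 nM to 300000 nM.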

Compound 4, half-maximal inhibitory concentration: 14000 nM
Compound 4: middle estimate off by 7.1-fold (0.85 log units), on the high side; measured number outside the range, below it.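

In this assay the group on the amide-type nitrogen now shows a readable effect: phenyl in place of benzyl gives an at least 7.1-fold lower number from compound 3 to compound 4 (0.85 log units; beyond the scatter). Substitution on the aromatic carbon of the anilide also counts, since hydrogen in place of chloro gives an at least 7.1-fold lower number from compound 2 to compound 4 (0.85 log units; beyond the scatter) and hydrogen in place of methyl gives an at least 7.1-fold lower number from compound 1 to compound 4 (0.85 log units; beyond the scatter). Among these four compounds only the unsubstituted anilide, compound 4, reads as a number, and the others remain at a limit of the assay: the limit of > 100000 nM in this assay, at which 3 of the 4 values shown sit.

From the compounds shown here alone, each of the three steps has only a lower bound, so its true size stays open. Also open, going by these compounds, is whether a fluoro, methoxy or amino group on that aromatic carbon, or a chain longer than benzyl on the amide-type nitrogen, would keep a readable value.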